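This account rests on a few compounds, and the source may have more. Where it says the series, first, only, none or still open, it means among the compounds named here.

Of the compounds shown here, three have been tested in a functional assay on HCT-116 cells (Homo sapiens) for antiproliferative activity, read by CCK-8 assay, with a stated time of 72 h, tested at 2 uM; a lower number here means a weaker effect, a higher number a stronger effect of the compound at the concentration tested. Compound 1 `CC1CCN(c2nc(Cl)nc3c2ncn3Cc2ccc(/C=C/C(=O)Nc3ccccc3N)cc2)CC1` gives 4.24%. Compound 2 `Nc1ccccc1NC(=O)c1ccc(Cn2cnc3c(Nc4ccc(-c5ccccn5)cc4)nc(Cl)nc32)cc1` gives 69.5%. Compound 3 `Nc1ccccc1NC(=O)c1ccc(COCNc2nc(Nc3ccccc3)c3ncn(C4CCCC4)c3n2)cc1` gives 75.2%, the highest of the three numbers, though its gap to compound 2 lies within the scatter of repeated measurements, so the two cannot be ordered; its gap to compound 1 lies well beyond the scatter.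

Compound 4 `CCCCn1cnc2c(Nc3ccccc3)nc(NCOCc3ccc(C(=O)Nc4ccccc4N)cc3)nc21` has not been measured. It differs from compound 3 in one place: butyl in place of cyclopentyl on an aromatic nitrogen. Both groups are made of carbon only and carry no hydrogen-bond donor or acceptor, so the change is a small one in size and shape on the same ring nitrogen.

Going by the values given here, no pair of measured compounds shows the effect of such a change, so the step from compound 3 to compound 4 in this assay is expected to be small, in no clear direction, and not beyond the scatter, as a number 5.2 percentage points lower from compound 3 to compound 4 (within the scatter) states. Compound 4 is therefore estimated to reach 70%, within a range from 50% to 85%.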

Compound 4, a percentage reported as inhibition, at one concentration (the size of the read-out at that concentration, not a potency): 72.9%
Beside the measured number, compound 4's estimate is 2.9 percentage points below it, within the range that was stated.
By their numbers in this assay, from the lowest: compound 1; then compounds 2, 4 and 3 (each within the scatter of the next).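

Going by these compounds alone, compound 3 and compound 4 form the first measured pair that differs in one place, so they give the first direct reading at this aromatic nitrogen. In this assay, putting butyl, which has no ring, in place of cyclopentyl gives a step (a number 2.3 percentage points lower from compound 3 to compound 4 (within the scatter)) that does not separate the two compounds, so at this position and with this shared core, the closed carbon ring is not needed to keep the read-out at this level. No measured evidence is available to explain this result.

Both groups are made of carbon only, so this pair cannot show whether a much shorter chain such as methyl, a longer chain such as octyl, or a chain ending in an amine or a carboxylic acid would be tolerated here. As the read-out comes from one concentration, it also leaves open whether the potencies of compound 3 and compound 4 match.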